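Propargyl ether of the hydroxyethyl benzimidazole series

The compounds below may be only part of what the source reports. "The series", "measured", "known", "first", "only" and "open" are said of these compounds alone.

Compound 2 `CN1CCN(c2nc3ccccc3n2CCO)CC1` stands at the weak end of the three measured compounds: in a functional assay on ileum for inhibition of histamine H1 receptor (Cavia porcellus) (on this read-out lower numbers stand for stronger inhibition and higher numbers for weaker inhibition), compound 2 gives 410 nM, the highest number of the set. Compound 1 `CCCOCCn1c(N2CCCN(C)CC2)nc2ccccc21` gives 16 nM in this assay, and compound 3 `CCCCCN1CCCN(c2nc3ccccc3n2CCOCC)CC1` gives 7.4 nM; both carry an ether in place of the free hydroxy and both sit far below compound 2. Compound 4 `C#CCOCCn1c(N2CCN(C)CC2)nc2ccccc21` differs from compound 2 by propargyl in place of hydrogen on an oxygen on a saturated carbon. Among the measured compounds shown here, no measured pair isolates this change, so the expectation rests on the two ether compounds. A large drop in number is expected, of the order of the step from compound 2 to compound 4 a 10-fold lower number from compound 2 to compound 4 (1.01 log units; beyond the scatter). For compound 4 the estimated value is 40 nM, expected between 12 nM and 130 nM.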

Compound 4, half-maximal inhibitory concentration: 12 nM
Beside the measured number, compound 4's estimate is 3.3-fold (0.52 log units) above it; the measured number falls inside the stated range.
By their numbers in this assay, from the lowest: compounds 3, 4 and 1 (each within the scatter of the next, the first and the last beyond it); then compound 2.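

Propargyl on the oxygen of the 2-hydroxyethyl chain, with the rest of the structure unchanged, gives in this assay a 34-fold lower number from compound 2 to compound 4 (1.53 log units; beyond the scatter). Among the compounds shown here, this is the first reading of the oxygen substituent alone, since compounds 1 and 3 differ from compound 2 in more than one place. Nothing at hand accounts for the size of this step.

As far as these compounds go, whether the triple bond matters, or any ether at this oxygen would do, remains open. A propyl or methyl ether on the core of compound 4 would separate the two, and an amine in place of the oxygen would test the oxygen itself.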